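The source may report more compounds than this note shows. Statements on the series, on what has been measured and on what is new or still open speak of the compounds shown alone.

Measured in a physicochemical assay for lipophilicity; a lower number here means a more polar compound, a higher number a more lipophilic compound:
- compound 1 `CCCCCCN(CCCCCSc1nc2ccccc2o1)C(=O)Nc1ccc(F)cc1F`: 7.18
- compound 2 `CCCCCCN(CCCCCSc1nc2ccccc2s1)C(=O)Nc1ccc(F)cc1F`: 7.78
- compound 3 `CCCCCCN(CCCCCSc1nc2cc(C)ccc2[nH]1)C(=O)Nc1ccc(F)cc1F`: 7.79

Compound 3 stands level with compound 2, the gap being a number 0.01 log units higher from compound 2 to compound 3 (within the scatter). Both lie clear of compound 1, with a number 0.61 log units higher from compound 1 to compound 3 (beyond the scatter) and a number 0.60 log units higher from compound 1 to compound 2 (beyond the scatter).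

Compound 4 `CCCCCCN(CCCCCSc1nc2cc([N+](=O)[O-])ccc2[nH]1)C(=O)Nc1ccc(F)cc1F` is the next to be read. It has nitro in place of methyl on an aromatic carbon, turning 5-methyl-1H-benzimidazol-2-yl into 5-nitro-1H-benzimidazol-2-yl: nitro in place of methyl on an aromatic carbon.

Within the data shown here, no measured step exchanges this substituent alone. The steps from compound 1 replace the whole group on the sulfur, so they offer only a guide to size, and that size is modest. The direction rests on the structural change alone, since nitro brings hydrogen-bond acceptors where methyl has none. A modest downward move in this assay is therefore expected, beyond the scatter but uncertain.

The expected step is a number 0.54 log units lower from compound 3 to compound 4 (beyond the scatter).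

For compound 4 the estimated value is 7.25, with an expected range of 6.85 to 7.65.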

Compound 4, partition coefficient: 7.19
For compound 4 the middle estimate is 0.06 log units above the measured one; measured number inside the range.
By their numbers in this assay, from the lowest: compounds 1 and 4 (each within the scatter of the next); then compounds 2 and 3 (each within the scatter of the next).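

In this assay, among these compounds, the exchange of methyl for nitro gives the first reading of a change at this aromatic carbon alone (a number 0.60 log units lower from compound 3 to compound 4 (beyond the scatter)), and this single substituent moves the number by a modest step, comparable with the earlier replacements of the whole group on the sulfur. Those replacements now also place 5-nitro-1H-benzimidazol-2-yl clear of 1,3-benzothiazol-2-yl (a number 0.59 log units lower from compound 2 to compound 4 (beyond the scatter)) but level with 1,3-benzoxazol-2-yl (a number 0.01 log units higher from compound 1 to compound 4 (within the scatter)), so the substituent here decides which of the two other groups the benzimidazole matches. Nothing shown here accounts for the size of this step.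

With only methyl and nitro shown at this aromatic carbon, where an amine, a methoxy group or a carboxylic acid would fall in this assay stays open. Also open, as far as these compounds go, is whether nitro would give a step of similar size on 1,3-benzoxazol-2-yl or 1,3-benzothiazol-2-yl.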